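Hydroxy for Trifluoromethyl on a Thiazolyl Alkyne

The source may report more compounds than this note shows. Statements on the series, on what has been measured and on what is new or still open speak of the compounds shown alone.

Compound 1 `Cc1nc(C#Cc2cccc(C(F)(F)F)c2)cs1` is one of three alkynes examined in a functional assay on CHO cells for agonist activity at metabotropic glutamate receptor 5 (Homo sapiens), read by inositol phosphate accumulation (a higher number here means a weaker inhibitor, a lower number a stronger inhibitor), where compound 1 gives 413 nM. Compound 3 `Cc1nc(C#Cc2cncc(Br)c2)cs1` gives 60 nM in this assay, a lower number that lies beyond the usual scatter, so compound 1 holds the higher of the two numbers recorded. For compound 2 `Cc1nc(C#Cc2cccnc2)c(-c2ccccc2)s1` this assay returns only a limit, > 10000 nM, which is the limit of > 10000 nM in this assay, at which 1 of the 3 values shown sits. Compound 4 `Cc1nc(C#Cc2cccc(O)c2)cs1` differs from compound 1 by hydroxy in place of trifluoromethyl on an aromatic carbon. Within the data shown here, no step between measured compounds covers this change. The move from compound 1 to compound 4 is expected to raise the number in this assay, by an estimated 3.6-fold higher number from compound 1 to compound 4 (0.56 log units; beyond the scatter) beyond the scatter. Compound 4 is accordingly estimated at 1500 nM, within 300 nM to 8000 nM.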

Compound 4, half-maximal inhibitory concentration: 654 nM
Compound 4: the middle estimate sits 2.3-fold (0.36 log units) above what was measured; low and high end bracket the measured number.
By their numbers in this assay, from the lowest: compound 3; then compounds 1 and 4 (each within the scatter of the next). At a limit, above all of these: compound 2.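

In this assay, hydroxy in place of trifluoromethyl on an aromatic carbon gives a 1.6-fold higher number from compound 1 to compound 4 (0.20 log units; within the scatter) and so leaves compound 1 and compound 4 not told apart. At this position on the six-membered aromatic ring of carbon only, the two groups therefore read alike, although only hydroxy counts a hydrogen-bond donor and a hydrogen-bond acceptor. Nothing measured among these compounds accounts for this likeness.

The compounds shown leave open how an amine, a methoxy group or a carboxylic acid would read at this same position.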